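This account rests on a few compounds, and the source may have more. Where it says the series, first, only, none or still open, it means among the compounds named here.

Working notes on the series in a functional assay on RAW264.7 cells (Rattus norvegicus) for inhibition, with RAW264.7 (Mus musculus) as the target, read by Griess assay, with stated times of 2 h and 16 h; on this read-out higher numbers stand for weaker inhibition and lower numbers for stronger inhibition.

Compound 1 `O=C1c2cc(O)ccc2O[C@H](c2cccc(O)c2O)[C@H]1O` is inactive up to the limit of the assay. In this assay compound 1 gives > 100000 nM, which is a limit and not a measured number. Compound 2 `COc1ccc2c(c1)C(=O)[C@@H](O)[C@H](c1cccc(O)c1O)O2` behaves in the same way. In this assay compound 2 gives > 100000 nM, again a limit rather than a number. Compound 2 therefore stands nowhere in particular on the numbers shown: both values sit at the limit of > 100000 nM in this assay, at which 2 of the 2 values shown sit, and no step between measured compounds can be drawn.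

Compound 3 `O=C1c2cc(O)ccc2O[C@@H](c2cccc(O)c2O)[C@@H]1O` is not yet measured. It differs from compound 2 by hydrogen in place of methyl on an oxygen on an aromatic ring. With both known values at the assay limit, no step of a defined size can be expected, and a change that would lift compound 3 beyond the scatter into a measurable range has no support in the shown data. The step from compound 2 to compound 3 is expected to be a number no higher from compound 2 to compound 3 (the limit leaves the size open). Compound 3 is expected to give about 100000 nM, within 30000 nM to 300000 nM, most likely reported only as a limit.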

Compound 3, half-maximal inhibitory concentration: > 100000 nM
Compound 3: only a limit was reported; the forecaster's own chance of this, stated with the estimate: 80%; the middle value sits exactly at the limit.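

In this assay compound 3 gives > 100000 nM, a limit and not a number. No step to compound 3 from compound 2 or compound 1 can be read: the limit of > 100000 nM in this assay, at which 3 of the 3 values shown sit.

The compounds shown leave open whether methoxy to hydroxy or the inverted configuration affects inhibition at all.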